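The source may hold more compounds than are shown below. What is called first, only, known or untested is meant among the compounds shown, and "the series" means these compounds.

In a functional assay on the whole organism (Hindlimb, strain albino) with Mus musculus as the target, in the maximal electroshock model, with a stated time of 0.5 h (on this read-out higher numbers stand for an effect only at larger amounts of compound and lower numbers for an effect already at smaller amounts), compound 1 `COc1ccc(C2CC(Nc3nc4ccc([N+](=O)[O-])cc4s3)=NN2C(C)=O)cc1O` gives 178 umol/kg and compound 2 `CC(=O)N1N=C(Nc2nc3ccc([N+](=O)[O-])cc3s2)CC1c1ccc(Cl)cc1` gives 132 umol/kg as its number. Compound 3 `CC(=O)N1N=C(Nc2nc3ccc(C)cc3s2)CC1c1ccccc1` gives 106 umol/kg here, and its gaps to both others lie within the usual scatter of repeated measurements, so it holds no clear place among the three.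

Compound 4 `CC(=O)N1N=C(Nc2nc3ccc([N+](=O)[O-])cc3s2)CC1c1ccccc1` differs from compound 3 in one place, with nitro in place of methyl on an aromatic carbon. Going by the values given here, no measured pair shows this exchange alone. Among the compounds with values here, the only single-place step available (a 1.3-fold lower number from compound 1 to compound 2 (0.13 log units; within the scatter)) lies elsewhere in the molecule and stays within the scatter, so it says little about the size of this one. More useful is that nitro already sits on compound 1 (178 umol/kg) and on compound 2 (132 umol/kg). Both values lie within the scatter of the methyl-bearing compound 3 (106 umol/kg), though those two nitro compounds also carry a different substituted phenyl.

In this assay no step beyond the scatter is therefore expected, and the estimated step is small (a 1.2-fold higher number from compound 3 to compound 4 (0.07 log units; within the scatter)) in either direction. Compound 4 is expected at 125 umol/kg as a middle value, with an estimated range from 65 umol/kg to 240 umol/kg for the measurement.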

Compound 4, dose for half-maximal effect: 216 umol/kg
Compound 4: middle estimate off by 1.7-fold (0.24 log units), on the low side; the range from low to high includes it.
By their numbers in this assay, from the lowest: compounds 3, 2, 1 and 4 (each within the scatter of the next, the first and the last beyond it).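

In this assay, going by these compounds alone, the exchange at this position can now be read directly for the first time: nitro in place of methyl on an aromatic carbon gives a modest step that lies just beyond the scatter (a 2.0-fold higher number from compound 3 to compound 4 (0.31 log units; beyond the scatter)), so with the same unsubstituted phenyl, the nitro compound needs a larger amount for the same effect. The substituent on the phenyl ring shows no clear influence among the nitro compounds, since hydrogen in place of chloro (a 1.6-fold higher number from compound 2 to compound 4 (0.21 log units; within the scatter)) and phenyl in place of 3-hydroxy-4-methoxyphenyl (a 1.2-fold higher number from compound 1 to compound 4 (0.08 log units; within the scatter)) both stay within the scatter. No measurement at hand offers a reason for the step from methyl to nitro.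

The compounds shown hold only nitro and methyl at this aromatic carbon, so what an amine, a carboxylic acid or a longer chain would do there remains open. This exchange also rests on one pair, which leaves open whether it would keep its size with chloro or with 3-hydroxy-4-methoxyphenyl in place of the unsubstituted phenyl.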